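Urea alkyl change on the anilino core

A few compounds are considered here, and "the series" means these few. Any claim that something is new, unique, unknown or untested is made for them only; others in the source may bear on it.

Compound 3 `Cc1ccccc1Nc1ccc(C#N)cc1S(=O)(=O)NC(=O)NC(C)(C)C` stands second highest of the three numbers in a functional assay on HEK293 cells for antagonist activity at thromboxane A2 receptor (Homo sapiens), read by fluorescence and calcium flux (on this read-out higher numbers stand for weaker inhibition and lower numbers for stronger inhibition), with a value of 2750 nM. Compound 1 `CCCCCNC(=O)NS(=O)(=O)c1cc(C#N)ccc1Oc1cccc(C)c1` gives 1330 nM in this assay, and compound 2 `Cc1ccccc1Nc1ccc(C#N)cc1S(=O)(=O)NC(=O)NC(C)C` gives 7240 nM. Within the data shown here, the only measured step of a single change, a 2.6-fold lower number from compound 2 to compound 3 (0.42 log units; beyond the scatter), runs toward a lower number as the alkyl group on the amide-type nitrogen grows.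

Compound 4 `CCCCCNC(=O)NS(=O)(=O)c1cc(C#N)ccc1Nc1ccccc1C` differs from compound 3 in one place: pentyl in place of tert-butyl on an amide-type nitrogen. Among the measured compounds shown here, no measured pair shows exactly this change. The step from compound 2 to compound 3 bears on it only as a general pointer, in that a larger alkyl group on that nitrogen gave a modestly lower number there, and pentyl is the larger group here. Compound 1 carries the pentyl group on a different core, and its value is lower than that of compound 3; the two are not a single-change pair, so this is noted only as what the two values show. A small downward step, near the edge of the scatter, is therefore expected: a 1.7-fold lower number from compound 3 to compound 4 (0.24 log units; within the scatter). For compound 4 the estimated value in this assay is 1600 nM, with a range from 550 nM to 4700 nM.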

Compound 4, half-maximal inhibitory concentration: 3190 nM
The estimate for compound 4 lay 2.0-fold (0.30 log units) below the measured number; the range from low to high includes it.
By their numbers in this assay, from the lowest: compound 1; then compounds 3 and 4 (each within the scatter of the next); then compound 2.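

On the shared core, pentyl and tert-butyl on the amide-type nitrogen are not separated in this assay (a 1.2-fold higher number from compound 3 to compound 4 (0.06 log units; within the scatter)), while pentyl still holds an advantage over isopropyl (a 2.3-fold lower number from compound 2 to compound 4 (0.36 log units; beyond the scatter)), so both of these groups sit apart from isopropyl but not from each other, and compound 4 goes against any reading that more carbons on this nitrogen keep lowering the number. With pentyl held constant, the other single-place comparison shows that this nitrogen is not the only place that moves the read-out: the number rises modestly when (2-methylphenyl)amino replaces 3-methylphenoxy on the aromatic carbon (a 2.4-fold higher number from compound 1 to compound 4 (0.38 log units; beyond the scatter)), a change of greater size than the one between pentyl and tert-butyl. No evidence is available that bears on these differences.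

As far as these compounds go, whether a longer chain such as heptyl, or a cyclohexyl group, on the amide-type nitrogen would give a number apart from those of compound 3 and compound 4 remains open. Also open, from the compounds shown here alone, is how the step from the phenoxy to the amino group divides between the linking atom and the place of the methyl group, which a pair built on (3-methylphenyl)amino or 2-methylphenoxy could separate.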